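A few compounds are considered here, and "the series" means these few. Any claim that something is new, unique, unknown or untested is made for them only; others in the source may bear on it.

Measured compounds in an assay on HeLa cells for displacement of a labelled ligand from 5-hydroxytryptamine receptor 6 (Homo sapiens), with a stated time of 2 h; on this read-out higher numbers stand for weaker inhibition and lower numbers for stronger inhibition:
- compound 1 `O=S(=O)(c1cccc(F)c1)c1cn(C2CCCNC2)c2ccc(F)cc12`: 4 nM
- compound 2 `CN1CCC(n2cc(S(=O)(=O)c3cccc(F)c3)c3ccccc32)C1`: 3.5 nM
- compound 3 `O=S(=O)(c1cccc(F)c1)c1cn(C2CCNC2)c2ccc(F)cc12`: 9.6 nM

Compound 3 gives the highest number of the three. Its nearest neighbour is compound 1, reached by the step of a 2.4-fold higher number from compound 1 to compound 3 (0.38 log units; beyond the scatter) for pyrrolidin-3-yl in place of piperidin-3-yl on the aromatic nitrogen. Compound 2 lies further off still.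

Compound 4 `CN1CCC(n2cc(S(=O)(=O)c3cccc(F)c3)c3cc(F)ccc32)C1` is not yet measured. It differs from compound 3 by methyl in place of hydrogen on an amine nitrogen in a ring, that is, pyrrolidin-3-yl to 1-methylpyrrolidin-3-yl.

Going by the values given here, no measured pair isolates this change. The closest guide is compound 1 against compound 2, which differ in two places, the methyl on the ring amine nitrogen and the fluorine on the core; their values in this assay sit within the scatter of each other, so the two changes together leave the number roughly where it was. On that basis the methyl on the pyrrolidine amine nitrogen is expected to shift the number little, a 1.2-fold lower number from compound 3 to compound 4 (0.08 log units; within the scatter), in no direction beyond the scatter. Compound 4 is therefore estimated at 8 nM, within a range of 3 nM to 22 nM.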

Compound 4, inhibition constant: 5 nM
Compound 4: the middle estimate sits 1.6-fold (0.20 log units) above what was measured; the range from low to high includes it.
By their numbers in this assay, from the lowest: compounds 2, 1, 4 and 3 (each within the scatter of the next, the first and the last beyond it).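

In this assay the methyl on the amine nitrogen of the pyrrolidine can now be read alone, and the step stays within the scatter: a 1.9-fold lower number from compound 3 to compound 4 (0.28 log units; within the scatter). The fluoro on the aromatic carbon is also isolated here, again within the scatter at a 1.4-fold higher number from compound 2 to compound 4 (0.15 log units; within the scatter), and with the methyl present the ring swap gives a 1.3-fold higher number from compound 1 to compound 4 (0.10 log units; within the scatter), whereas without the methyl the step of a 2.4-fold higher number from compound 1 to compound 3 (0.38 log units; beyond the scatter) lies beyond it. Nothing available bears on why these steps come out as they do.

As far as these compounds go, whether an ethyl, a longer chain or an acetyl on the same amine nitrogen would also stay within the scatter remains open. The compounds shown also leave open how a methyl on the piperidin-3-yl amine nitrogen would read.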